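The source may report more compounds than this note shows. Statements on the series, on what has been measured and on what is new or still open speak of the compounds shown alone.

Of the compounds shown here, three sharing one core have been tested for how much of them cultured dog kidney cells tolerate. Compound 1 `CCCOc1ccc(CN(Cc2ccc(C(C)(C)C)cc2)Cc2cc3cc(C)ccc3[nH]c2=O)cc1` is the starting point. In a toxicity assay on MDCK cells (Canis lupus familiaris) for cytotoxicity, read by crystal violet staining, with a stated time of 48 h (a lower number here means that less compound is tolerated, a higher number that more compound is tolerated), compound 1 gives > 5000 nM, which is a limit of the assay rather than a number. Compound 2 `CCCCOc1ccc(CN(Cc2ccc(C(C)(C)C)cc2)Cc2cc3cc(C)ccc3[nH]c2=O)cc1` differs from compound 1 by methyl in place of hydrogen on a saturated chain carbon, three bonds along the chain from an oxygen on an aromatic ring. In this assay compound 2 gives > 5000 nM, again a limit of the assay. Compound 3 `Cc1ccc2[nH]c(=O)c(CN(Cc3ccc(C(C)(C)C)cc3)Cc3ccc(N(C)C)c(Cl)c3)cc2c1` differs from compound 1 in its core by 3-chloro-4-(dimethylamino)phenyl in place of 4-propoxyphenyl on a saturated chain carbon bound to an amine nitrogen. In this assay compound 3 gives > 10000 nM, also only a limit of the assay. Of the three values, two sit at the limit of > 5000 nM in this assay, at which 2 of the 3 values shown sit, and one at the limit of > 10000 nM in this assay, at which 1 of the 3 values shown sits. The steps a step that the two limits leave unreadable from compound 1 to compound 2, a step that the two limits leave unreadable from compound 1 to compound 3 and a step that the two limits leave unreadable from compound 2 to compound 3 therefore carry no readable size.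

Compound 4 `Cc1ccc2[nH]c(=O)c(CN(Cc3ccc(C(C)(C)C)cc3)C(C)c3ccc(N(C)C)c(Cl)c3)cc2c1` is not yet measured and differs from compound 3 by methyl in place of hydrogen on a saturated chain carbon bound to an amine nitrogen and an aromatic carbon. The same kind of change was made from compound 1 to compound 2, where the methyl enters on a saturated chain carbon, three bonds along the chain from an oxygen on an aromatic ring, whereas in compound 4 it enters on a saturated chain carbon bound to an amine nitrogen and an aromatic carbon. That earlier step, a step that the two limits leave unreadable from compound 1 to compound 2, showed no readable change, and compound 3 itself sits at > 10000 nM, so little movement is expected. The expected step is a step that the limit leaves unreadable from compound 3 to compound 4. Compound 4 is thus estimated to land near 12000 nM, between 5000 nM and 40000 nM, most likely again as a limit.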

Compound 4, half-maximal cytotoxic concentration: 9800 nM
For compound 4 the middle estimate is 1.2-fold (0.09 log units) above the measured one; measured number inside the range.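

In this assay, methyl in place of hydrogen on a saturated chain carbon bound to an amine nitrogen and an aromatic carbon gives an at least 1.0-fold lower number from compound 3 to compound 4 (0.00 log units; that floor lies within the scatter), so this pair shows a floor for the step and does not show that the number truly shifts. As far as these compounds go, the real size of the step stays unknown because compound 3 has only a limit of the assay and not a number: the limit of > 10000 nM in this assay, at which 1 of the 4 values shown sits. This is also a single pair on a single core, and the steps from compound 1 and compound 2 to compound 4 cannot be read and change a whole group in any case, so nothing here shows whether the same methyl would act alike on another core, because those two compounds also stand at a limit: the limit of > 5000 nM in this assay, at which 2 of the 4 values shown sit.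

From the compounds shown here alone, what remains open is how the same methyl behaves on the saturated chain carbon of the 4-propoxybenzyl or 4-butoxybenzyl compounds, since a matched pair there would put this change on a second core. Going by these compounds, it is also open how an ethyl or a carboxylic acid at that same carbon would read, and whether either would give a number rather than a limit.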